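Triazole isomer swap on the sulfonyl sulfur of compound 3

A few compounds are considered here, and "the series" means these few. Any claim that something is new, unique, unknown or untested is made for them only; others in the source may bear on it.

Compound 3 `Cn1ncnc1S(=O)(=O)N1CCC(CNC(=O)c2ccc(Cl)cc2Cl)(CC2CC2)CC1` gives 314 nM in an assay on JAR cells for inhibition of sodium- and chloride-dependent glycine transporter 1 (Homo sapiens), read by scintillation counting, with a stated time of 3 h (a higher number here means a weaker inhibitor, a lower number a stronger inhibitor), the highest of the three numbers at hand. Compound 2 `Cn1nncc1S(=O)(=O)N1CC(CNC(=O)c2ccc(Cl)cc2Cl)(CC2CC2)C1` sits nearest, with 185 nM, a gap that falls within the scatter, so the two cannot be ordered. Compound 1 `Cn1cc(S(=O)(=O)N2CC(CNC(=O)c3ccc(Cl)cc3Cl)(CC3CC3)C2)cn1` stands furthest, with 3.62 nM in this assay. Going by the values given here, the one step measured in a single place, a 51-fold higher number from compound 1 to compound 2 (1.71 log units; beyond the scatter), is the only guide to how a change on the sulfonyl sulfur has moved this assay, and it concerns a different pair of rings on a different core.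

Compound 4 `Cn1cnnc1S(=O)(=O)N1CCC(CNC(=O)c2ccc(Cl)cc2Cl)(CC2CC2)CC1` differs from compound 3 in one place: 4-methyl-4H-1,2,4-triazol-3-yl in place of 1-methyl-1H-1,2,4-triazol-5-yl on a sulfonyl sulfur. Among the compounds with values here, no measured step covers this triazole-to-triazole exchange on the core of compound 3, so the step from compound 3 to compound 4 is expected to stay within the scatter, with no direction favoured, as a 1.0-fold lower number from compound 3 to compound 4 (0.02 log units; within the scatter). On that basis compound 4 is estimated at 300 nM in this assay, between 100 nM and 1000 nM.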

Compound 4, half-maximal inhibitory concentration: 124 nM
Compound 4: the middle estimate sits 2.4-fold (0.38 log units) above what was measured; low and high end bracket the measured number.
By their numbers in this assay, from the lowest: compound 1; then compounds 4, 2 and 3 (each within the scatter of the next, the first and the last beyond it).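

In this assay the sulfonyl sulfur on this core responds to the arrangement of the triazole alone: there is a 2.5-fold lower number from compound 3 to compound 4 (0.40 log units; beyond the scatter), a modest step beyond the scatter. The two triazolyl groups have the same atoms, joined differently, with equal counts of heavy atoms and hydrogen-bond acceptors and no net charge, so such counts do not settle the number at this position. Nothing at hand accounts for the step.

The compounds shown leave open how 1-methyl-1H-pyrazol-4-yl would read on the core of compound 4, and whether the triazole exchange would move the number the same way on the core of compound 1. Also open, as far as these compounds go, is how a phenyl ring or a dimethylamino group would read on the sulfonyl sulfur.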